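The source may report more compounds than this note shows. Statements on the series, on what has been measured and on what is new or still open speak of the compounds shown alone.

The measured compounds:
compound 1, `S=C(Nc1ccccc1)OCCc1ccccn1`: > 100000 nM
compound 2, `Cc1ccccc1NC(=S)OCCc1ccccn1`: > 100000 nM

In an ADME assay on MT4 cells (Homo sapiens) for cytotoxicity, read by MTT assay (on this read-out higher numbers stand for lower toxicity in this test and lower numbers for higher toxicity in this test), compound 1 gives only a limit of the assay, > 100000 nM. Compound 2 likewise reaches only a limit in this assay, > 100000 nM. Within the data shown here, the single measured step, a step that the two limits leave unreadable from compound 1 to compound 2, therefore has no readable size, since both of its ends sit at the limit of > 100000 nM in this assay, at which 2 of the 2 values shown sit. Compound 3, `Fc1cccc(NC(=S)OCCc2ccccn2)c1`, is not yet measured. It differs from compound 1 by fluoro in place of hydrogen on an aromatic carbon. Among the measured compounds shown here, no measured step covers this change, and the only step at hand yields no size; the two measured values, both limits, show no direction either. Compound 3 is thus expected to stay near the same limit in this assay, with no step beyond the scatter, so that a step that the limit leaves unreadable from compound 1 to compound 3 is the expected step. The estimate for compound 3 in this assay is 150000 nM, with a range from 60000 nM to 600000 nM.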

Compound 3, half-maximal cytotoxic concentration: >= 100000 nM
Compound 3: only a limit was reported; the forecaster's own chance of this, stated with the estimate: 85%; the middle value lies beyond the limit too.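

Compound 1 and compound 3 both reach only limits in this assay, and the step between them cannot be read. The compounds shown leave open how far past these limits any of the three lies, and whether the methyl or the fluoro changes anything in this assay.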